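Methoxy to methyl on the benzyloxy ring

The compounds below may be only part of what the source reports. "The series", "measured", "known", "first", "only" and "open" are said of these compounds alone.

Compound 1 `Cn1c(=O)c2c(nc(COc3cccc(Br)c3)n2C)n(C)c1=O` in an in vitro assay on cells for inhibition of Amine oxidase [flavin-containing] A (Homo sapiens), read by coupled enzyme assay, with a stated time of 20 min (a higher number here means a weaker inhibitor, a lower number a stronger inhibitor), gives 34000 nM, a weak result. Compound 2 `COc1cccc(OCc2nc3c(c(=O)n(C)c(=O)n3C)n2C)c1` is reported in this assay as "not active" (no number reported), so no single number stands for it. Compound 3 `Cc1cccc(OCc2nc3c(c(=O)n(C)c(=O)n3C)n2C)c1` differs from compound 2 by methyl in place of methoxy on an aromatic carbon, meta to a large group. Among the measured compounds shown here, no measured step covers this change; given that compound 2 shows "not active" (no number reported) and compound 1 shows 34000 nM, no shift beyond the scatter toward stronger inhibition is expected. Compound 3 is estimated at 60000 nM, range 20000 nM to 200000 nM, with a fair chance that only a limit is reported.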

Compound 3, half-maximal inhibitory concentration: 18800 nM
Estimate against measurement, compound 3: 3.2-fold (0.50 log units) above; measured number below the stated range.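

In this assay compound 3, with the 3-methylphenyl group, gives 18800 nM, whereas compound 2, with the 3-methoxyphenyl group, is reported as "not active" (no number reported), so the methoxy-to-methyl change has no step size that can be read. Methyl in place of bromo on this aromatic carbon gives a 1.8-fold lower number from compound 1 to compound 3 (0.26 log units; within the scatter), so the two compounds with numbers are not separated in this assay. No measured evidence accounts for these results.

From the compounds shown here alone, whether an amine, a carboxylic acid or a longer chain at this place would give a step beyond the scatter remains open. Going by these compounds, the unsubstituted phenyl ring also remains open as a reference.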